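Alkenyl chain change: cyclohexyl in place of methoxyphenyl

A few compounds are considered here, and "the series" means these few. Any claim that something is new, unique, unknown or untested is made for them only; others in the source may bear on it.

Values in a functional assay on HeLa cells (Homo sapiens) for cytotoxicity, read by WST assay, with a stated time of 48 h (on this read-out higher numbers stand for weaker inhibition and lower numbers for stronger inhibition), for the measured compounds:
compound 1 `COc1cccc(/C=C/C[C@H]2C[C@@H]([C@@H](O)c3ccccc3)CO[C@@H]2c2ccccc2)c1` — 10900 nM
compound 2 `COc1ccc([C@H]2OC[C@H]([C@@H](O)c3ccc(OC)c(OC)c3)C[C@@H]2C/C=C/c2ccccc2)cc1OC` — 14800 nM
compound 3 `COc1ccc(CCC[C@@H]2C[C@@H]([C@@H](O)c3ccc(OC)c(OC)c3)CO[C@H]2c2ccc(OC)c(OC)c2)cc1OC` — 35700 nM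

Compound 1 gives the lowest of the three numbers shown. Compound 2 sits within the scatter of it, so no order between the two is claimed; compound 3 lies beyond the scatter on the higher side.

Compound 4 `O[C@@H](c1ccccc1)[C@H]1CO[C@H](c2ccccc2)[C@@H](C/C=C/C2CCCCC2)C1` is not yet measured. Against compound 1 the difference is cyclohexyl in place of 3-methoxyphenyl on a double-bonded chain carbon bound to a double-bonded chain carbon. Among the measured compounds shown here, no pair of measured compounds shares this change, so nothing sizes it. In this assay a step of no more than the scatter is expected, if anything toward a higher number. Compound 4 is estimated at 15000 nM (range 5000 nM to 45000 nM), an expected step of a 1.4-fold higher number from compound 1 to compound 4 (0.14 log units; within the scatter).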

Compound 4, half-maximal inhibitory concentration: 6440 nM
For compound 4 the middle estimate is 2.3-fold (0.37 log units) above the measured one; measured number inside the range.
By their numbers in this assay, from the lowest: compounds 4, 1 and 2 (each within the scatter of the next, the first and the last beyond it); then compound 3.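

In this assay the change from 3-methoxyphenyl to cyclohexyl on a double-bonded chain carbon bound to a double-bonded chain carbon gives a 1.7-fold lower number from compound 1 to compound 4 (0.23 log units; within the scatter) and so no change that can be read. At this place, then, an aromatic ring and the hydrogen-bond acceptor of the leaving group are not needed for the number to stay at this level. No measurement here explains the result.

On these data alone, whether a tert-butyl group or a piperidine at this place would hold the same level remains open. So does whether any group here can produce a step beyond the scatter.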